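The source may report more compounds than this note shows. Statements on the series, on what has been measured and on what is new or still open speak of the compounds shown alone.

Compounds measured in a functional assay on A549 cells (Homo sapiens) for antiproliferative activity, read by MTT assay; on this read-out lower numbers stand for stronger inhibition and higher numbers for weaker inhibition:
- compound 1 `Cn1c(=O)c(=O)n(C2CCCC2)c2nc(N/N=C/c3ccco3)ncc21`: > 100000 nM (a limit of the assay, not a number)
- compound 2 `Cn1c(=O)c(=O)n(C2CCCC2)c2nc(N/N=C/c3ccccc3F)ncc21`: 31200 nM
- compound 3 `COc1cc(/C=N/Nc2ncc3c(n2)n(C2CCCC2)c(=O)c(=O)n3C)cc(OC)c1OC`: 18300 nM

From the compounds shown here alone, compound 1 stands at the far end of this set: in this assay compound 1 reaches only a limit, (the limit of > 100000 nM in this assay, at which 1 of the 3 values shown sits), so its true value is unknown beyond that. The step to compound 2 is the only measured one, an at least 3.2-fold lower number from compound 1 to compound 2 (0.50 log units; beyond the scatter). Compound 3 is also measured, but it differs from the others in more than one place, so its value is reported here without a step.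

The unmeasured compound 4 `Cn1c(=O)c(=O)n(C2CCCC2)c2nc(N/N=C/c3ccc(F)cc3F)ncc21` differs from compound 1 in one place: 2,4-difluorophenyl in place of furan-2-yl on a carbon with a double bond to nitrogen. Among the compounds with values here, the measured step that bears on it is the one to compound 2, where a fluorinated phenyl ring took the place of the furan ring and the number went down at least modestly. A step of similar size and direction is therefore expected from compound 1 to compound 4, an at least 3.3-fold lower number from compound 1 to compound 4 (0.52 log units; beyond the scatter). For compound 4 in this assay the estimate is 30000 nM, with a range from 10000 nM to 100000 nM.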

Compound 4, half-maximal inhibitory concentration: 18300 nM
The estimate for compound 4 lay 1.6-fold (0.21 log units) above the measured number; measured number inside the range.
By their numbers in this assay, from the lowest: compounds 3, 4 and 2 (each within the scatter of the next). At a limit, above all of these: compound 1.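

In this assay, a second fluoro on the phenyl ring does not separate the two fluorinated compounds: with fluoro in place of hydrogen on an aromatic carbon, the result is a 1.7-fold lower number from compound 2 to compound 4 (0.23 log units; within the scatter). Replacing furan-2-yl with 2,4-difluorophenyl at this carbon gives an at least 5.4-fold lower number from compound 1 to compound 4 (0.73 log units; beyond the scatter), so a second fluorinated phenyl ring also stands clear of the furan compound. The full size of that step remains unknown because compound 1 stands at a limit rather than a number: the limit of > 100000 nM in this assay, at which 1 of the 4 values shown sits.

From the compounds shown here alone, it remains open whether the fluoro groups matter at all, or whether a plain phenyl ring would give a similar value. A phenyl ring carrying an amine or a carboxylic acid is also untested among the compounds shown.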